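Benzyl to cyclohexylmethyl on two related amide cores

A few compounds are considered here, and "the series" means these few. Any claim that something is new, unique, unknown or untested is made for them only; others in the source may bear on it.

Compound 1 `O=C(NCc1ccccc1)c1cccc(N2C(=O)N/C(=C\c3ccc(O)cc3)C2=O)c1` and compound 2 `O=C(NCC1CCCCC1)c1cccc(N2C(=O)N/C(=C\c3ccc(O)cc3)C2=O)c1` share one core, while compound 3 `O=C(NCc1ccccc1)c1ccc(N2C(=O)N/C(=C\c3ccc(O)cc3)C2=O)cc1` and the not yet measured compound 4 `O=C(NCC1CCCCC1)c1ccc(N2C(=O)N/C(=C\c3ccc(O)cc3)C2=O)cc1` share another. The difference between the two cores is not broken down here; compound 1 and compound 3 contain the same atoms, joined differently.

In a functional assay on NCI-H292 cells (Homo sapiens) for antiproliferative activity (on this read-out higher numbers stand for weaker inhibition and lower numbers for stronger inhibition), compound 1 gives 23500 nM. In this assay compound 2 gives 17900 nM. The change that separates them is cyclohexyl in place of phenyl on a saturated chain carbon bound to an amide-type nitrogen, and it made a step of a 1.3-fold lower number from compound 1 to compound 2 (0.12 log units; within the scatter), so the two values are not told apart by this read-out.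

For compound 3 this assay reports no number, only a limit of the assay, > 200000 nM. This is the limit of > 200000 nM in this assay, at which 1 of the 3 values shown sits.

Compound 4 is reached from compound 3 by the same change, (cyclohexyl in place of phenyl on a saturated chain carbon bound to an amide-type nitrogen), at the same place in the molecule. Within the data shown here, since the first instance of this change gave only a 1.3-fold lower number from compound 1 to compound 2 (0.12 log units; within the scatter), a step of similar size is expected from compound 3 to compound 4 in this assay, namely a step that the limit leaves unreadable from compound 3 to compound 4, and because compound 3 already sits at the limit of > 200000 nM in this assay, at which 1 of the 3 values shown sits, compound 4 is expected most likely to be reported as a limit as well. Compound 4 is therefore estimated at 250000 nM in this assay, with a range from 100000 nM to 700000 nM.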

Compound 4, half-maximal inhibitory concentration: > 200000 nM
Compound 4 was reported as a limit (the forecaster's own chance of this, stated with the estimate: 75%); the middle value lies beyond the limit too.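

In this assay compound 4 gives > 200000 nM, which is a limit of the assay and not a number. No step can be read between compound 3 and compound 4, because both are reported only as limits: the limit of > 200000 nM in this assay, at which 2 of the 4 values shown sit.

The compounds shown leave open whether cyclohexyl in place of phenyl changes the read-out at all on the core of compound 3.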